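Chain lengthening on the ring amine nitrogen

The source may hold more compounds than are shown below. What is called first, only, known or untested is meant among the compounds shown, and "the series" means these compounds.

Measured compounds:
Compound 1, `CN1CCC(COC(c2ccccc2)c2ccccc2)CC1`. In a functional assay on cells (T-cell line, Homo sapiens) for inhibition (a lower number here means a stronger inhibitor, a higher number a weaker inhibitor), compound 1 gives > 20000 nM, which is a limit of the assay.
Compound 2, `CCN1CCC(COC(c2ccccc2)c2ccccc2)CC1`. Compound 2 gives > 20000 nM, likewise a limit of the assay.
Compound 3, `CCCCN1CCC(COC(c2ccccc2)c2ccccc2)CC1`. Compound 3 gives 14000 nM.

Among the compounds with values here, compound 3 carries the only number in the set; the other two sit at a limit (the limit of > 20000 nM in this assay, at which 2 of the 3 values shown sit). The step of an at least 1.4-fold lower number from compound 1 to compound 3 (0.15 log units; that floor lies within the scatter) and the step of an at least 1.4-fold lower number from compound 2 to compound 3 (0.15 log units; that floor lies within the scatter) are therefore read against a limit, and their floors lie within the scatter. The step that the two limits leave unreadable from compound 1 to compound 2 cannot be read at all.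

Compound 4, `CCCCCN1CCC(COC(c2ccccc2)c2ccccc2)CC1`, is not yet measured. Its change from compound 3 is methyl in place of hydrogen on a saturated chain carbon, four bonds along the chain from an amine nitrogen in a ring. The same kind of change was made from compound 1 to compound 2, (methyl in place of hydrogen on a saturated chain carbon bound to an amine nitrogen in a ring), but the places differ: there the new carbon sits on a saturated chain carbon bound to an amine nitrogen in a ring, in compound 4 on a saturated chain carbon four bonds along the chain from an amine nitrogen in a ring. The two cores differ by propyl in place of hydrogen on a saturated chain carbon bound to an amine nitrogen in a ring. The size of the earlier step, a step that the two limits leave unreadable from compound 1 to compound 2, is unreadable, so it sets no expectation.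

For compound 4 the expected step is a 1.8-fold lower number from compound 3 to compound 4 (0.24 log units; within the scatter); this rests on the floor-only steps an at least 1.4-fold lower number from compound 1 to compound 3 (0.15 log units; that floor lies within the scatter) and an at least 1.4-fold lower number from compound 2 to compound 3 (0.15 log units; that floor lies within the scatter), which end at compound 3 and its 14000 nM. In this assay compound 4 is expected to give 8000 nM, estimated between 3000 nM and 20000 nM.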

Compound 4, half-maximal inhibitory concentration: 10800 nM
Compound 4: the middle estimate sits 1.4-fold (0.13 log units) below what was measured; low and high end bracket the measured number.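

In this assay, methyl in place of hydrogen on a saturated chain carbon, four bonds along the chain from an amine nitrogen in a ring, gives a 1.3-fold lower number from compound 3 to compound 4 (0.11 log units; within the scatter), so this one step shows no change that can be told from the scatter. The two steps that start from a limit, an at least 1.8-fold lower number from compound 2 to compound 4 (0.26 log units; that floor lies within the scatter) and an at least 1.8-fold lower number from compound 1 to compound 4 (0.26 log units; that floor lies within the scatter), give floors only, so they establish no trend with chain length and no true size for either step. Whether the same change has the same size on two cores therefore stays undecided, and the series gives no firm basis for carrying a size from one core to another: the same change on two cores in this assay, an at least 1.4-fold lower number (0.15 log units; that floor lies within the scatter) from compound 1 to compound 3 and an at least 1.8-fold lower number (0.26 log units; that floor lies within the scatter) from compound 2 to compound 4; the limit leaves it open whether they differ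

From the compounds shown here alone, only compound 3 and compound 4 carry numbers in this set, and the other two values are limits, so the lower end of the chain series has no measured size: the limit of > 20000 nM in this assay, at which 2 of the 4 values shown sit. It remains open whether a longer chain on the ring amine nitrogen, such as hexyl or octyl, or a butyl chain ending in a carboxylic acid or a second amine, would give a step beyond the scatter in this assay.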